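The source may hold more compounds than are shown below. What is called first, only, known or untested is meant among the compounds shown, and "the series" means these compounds.

Compound 1, `CC(C)N(Cc1cccc(OCCCCCC(=O)O)c1)C(=O)c1ccc(-c2ccco2)cc1`, is reported in an ADME assay on Raji cells (Homo sapiens) for cytotoxicity, read by CellTiter-Glo and resazurin assay, with a stated time of 72 h (on this read-out higher numbers stand for an effect only at larger amounts of compound and lower numbers for an effect already at smaller amounts), only as the limit > 26000 nM.
Compound 2, `CCOC(=O)CCCCCOc1cccc(CN(C(=O)c2ccc(-c3ccco3)cc2)C(C)C)c1`, is reported in this assay only as the limit > 26000 nM.

For the measured compounds named here, compound 2 therefore has no numerical reading; it sits at the limit of > 26000 nM in this assay, at which 2 of the 2 values shown sit, where both values so far stand. Going by the values given here, the one step among the measured compounds, a step that the two limits leave unreadable from compound 1 to compound 2, cannot be sized, since both ends are limits. Compound 3, `CCOC(=O)CCCCCOc1cccc(CN(C(=O)c2ccc(-c3cccc(S(C)(=O)=O)c3)cc2)C(C)C)c1`, is the unmeasured compound; it differs from compound 2 by 3-(methylsulfonyl)phenyl in place of furan-2-yl on an aromatic carbon, at an aromatic carbon of a six-membered aromatic ring of carbon only, para to a large group. No measured step concerns this kind of exchange, and the single step shown gives no size at all, so there is nothing to set an expected direction or size from. Compound 3 is therefore expected to remain near the limit, with a step that the limit leaves unreadable from compound 2 to compound 3 expected to be no readable step. The estimate for compound 3 in this assay is 30000 nM, within a range from 8000 nM to 120000 nM, most likely again reported as a limit.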

Compound 3, half-maximal effective concentration: > 26000 nM
Compound 3 ended at the assay's limit; the forecaster's own chance of this, stated with the estimate: 80%; the middle value is on the limit's open side.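

For the compounds shown here, compound 2 and compound 3 are both reported in this assay only as a limit, so the exchange of furan-2-yl for 3-(methylsulfonyl)phenyl gives no step that can be read. The compounds shown leave open at what concentration any of them would reach a half-maximal effect, and whether either exchange changes that concentration at all: the limit of > 26000 nM in this assay, at which 3 of the 3 values shown sit.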